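The source may hold more compounds than are shown below. What is called first, only, known or untested is meant among the compounds shown, and "the series" means these compounds.

Compound 1, `CNc1ncccc1C(=O)N/N=C/c1ccccc1`, and compound 2, `CNc1ncccc1C(=O)N/N=C/c1cccnc1`, share a core and differ only in the ring attached to the carbon with a double bond to nitrogen. In a functional assay on the whole organism (strain Wistar) for inhibition, with Rattus norvegicus as the target, read by paw edema, with a stated time of 2 h, at a dose of 10 mg/kg by the intraperitoneal route (a higher number here means more inhibition at the dose given (going by the name of the read-out), a lower number less inhibition), compound 1 gives 47.2%, and in the same assay compound 2 gives 43.7%. Going by the values given here, the only measured step is a number 3.5 percentage points lower from compound 1 to compound 2 (within the scatter), so compound 2 holds the lowest of the two numbers, yet its gap to compound 1 lies within the scatter, and no order between the two can be read from it. Compound 3, `CNc1ncccc1C(=O)N/N=C/c1ccncc1`, has not been measured. It differs from compound 2 by pyridin-4-yl in place of pyridin-3-yl on a carbon with a double bond to nitrogen. Among the compounds with values here, no measured step bears directly on this exchange of one pyridinyl for another; the one step available moved a phenyl to a pyridin-3-yl and stayed within the scatter. Compound 3 is therefore expected to show a step of a number 0.7 percentage points lower from compound 2 to compound 3 (within the scatter), not beyond the scatter, and its estimated value in this assay is 43%, with a range from 32% to 54%.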

Compound 3, a percentage reported as inhibition, in the whole organism at one dose (the size of the read-out at that dose, not a potency): 60.4%
Compound 3: the middle estimate sits 17.4 percentage points below what was measured; measured number outside the range, above it.
By their numbers in this assay, from the lowest: compounds 2 and 1 (each within the scatter of the next); then compound 3.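

In this assay, the group on the carbon with a double bond to nitrogen proves able to shift the read-out: pyridin-4-yl in place of pyridin-3-yl gives a number 16.7 percentage points higher from compound 2 to compound 3 (beyond the scatter), although the two groups hold the same atoms, joined differently. Pyridin-4-yl in place of phenyl likewise gives a number 13.2 percentage points higher from compound 1 to compound 3 (beyond the scatter), whereas the earlier exchange of phenyl for pyridin-3-yl stayed within the scatter, so among these three groups the higher number goes with pyridin-4-yl alone and not with a pyridinyl ring as such. Nothing at hand explains why this one group stands apart.

As far as these compounds go, how pyridin-2-yl, or a phenyl ring carrying an amine or a carboxylic acid, would stand at this place remains open. So does whether the higher number of compound 3 holds at other doses or times.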